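A Second Methyl Next to the Benzylic Urea Link

The source may hold more compounds than are shown below. What is called first, only, known or untested is meant among the compounds shown, and "the series" means these compounds.

Among the three measured compounds, compound 2 `Cc1cc(C(=O)N2CCCCc3ccccc32)ccc1CNC(=O)Nc1c(F)cccc1F` gives the lowest number in a functional assay on HEK293 cells for agonist activity at Vasopressin V2 receptor (Homo sapiens), read by a luciferase reporter and cAMP accumulation (on this read-out lower numbers stand for an effect already at smaller amounts and higher numbers for an effect only at larger amounts of compound), at 2.1 nM. Compound 3 `CCc1cc(C(=O)N2CCCCc3ccccc32)ccc1CNC(=O)Nc1c(F)cccc1F` gives 10 nM, and compound 1 `O=C(NCc1ccc(C(=O)N2CCCCc3ccccc32)c(F)c1)Nc1c(F)cccc1F` gives 180 nM. Compound 4 `Cc1cc(C(=O)N2CCCCc3ccccc32)cc(C)c1CNC(=O)Nc1c(F)cccc1F` differs from compound 2 by methyl in place of hydrogen on an aromatic carbon. For the measured compounds named here, the only measured step that bears on adding carbon to this part of the molecule is a 4.8-fold higher number from compound 2 to compound 3 (0.68 log units; beyond the scatter), where the methyl grew into an ethyl and the number rose modestly. A further methyl on the ring is therefore expected to raise the number by a modest amount as well, though a change within the scatter cannot be excluded. Compound 4 is expected to give 6 nM, in the range 1.5 nM to 25 nM. The expected step is a 2.9-fold higher number from compound 2 to compound 4 (0.46 log units; beyond the scatter).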

Compound 4, half-maximal effective concentration: 82 nM
Compound 4: the middle estimate sits 14-fold (1.14 log units) below what was measured, and the stated range ends below it.
By their numbers in this assay, from the lowest: compound 2; then compound 3; then compound 4; then compound 1.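

In this assay the added methyl on an aromatic carbon, ortho to a large group, gives a 39-fold higher number from compound 2 to compound 4 (1.59 log units; beyond the scatter) and so a large step, whereas the growth of methyl into ethyl gave only a 4.8-fold higher number from compound 2 to compound 3 (0.68 log units; beyond the scatter) and so a modest one. One added carbon at this ring position thus weighs far more than one added carbon on the existing chain, and the smaller step did not carry over. Nothing shown accounts for the size of this step.

As far as these compounds go, whether fluorine or chlorine in place of this hydrogen would give a step of similar size stays open. So does what a methoxy group or an amine would do here.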